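Lengthening a chlorinated chain on a sulfonate ester anilide

The compounds below may be only part of what the source reports. "The series", "measured", "known", "first", "only" and "open" are said of these compounds alone.

Three compounds share an anilide whose aromatic ring carries a sulfonate ester linked to a second aromatic ring, and differ in what hangs on that second ring and in the chlorinated chain on the amide. Compound 1 `O=C(CCl)Nc1ccc(S(=O)(=O)Oc2ccccc2I)cc1` gives 4100 nM in a functional assay on HT-29 cells (Homo sapiens) for antiproliferative activity, read by sulforhodamine B assay, with a stated time of 48 h; a lower number here means a stronger inhibitor, a higher number a weaker inhibitor. Compound 3 `O=C(CCCl)Nc1ccc(S(=O)(=O)Oc2ccccc2I)cc1` gives 14000 nM, and compound 2 `CC(C)c1ccccc1OS(=O)(=O)c1ccc(NC(=O)CCCl)cc1` gives 16000 nM.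

Between compound 1 and compound 3 the change is chloromethyl in place of chloro on a saturated chain carbon bound to a carbonyl carbon, and the result is a 3.4-fold higher number from compound 1 to compound 3 (0.53 log units; beyond the scatter). Between compound 2 and compound 3 the change is iodo in place of isopropyl on an aromatic carbon, and the result is a 1.1-fold lower number from compound 2 to compound 3 (0.06 log units; within the scatter). The difference between the core of compound 1 and the core of compound 2 is not broken down here.

Compound 4 `CC(C)c1ccccc1OS(=O)(=O)c1ccc(NC(=O)CCCCl)cc1` has not been measured. It arises from compound 2 by chloromethyl in place of chloro on a saturated chain carbon, two bonds along the chain from a carbonyl carbon. Within the data shown here, this is the same kind of change as the one from compound 1 to compound 3, though it sits two bonds along the chain from a carbonyl carbon rather than on a carbon bound to a carbonyl carbon. Among the measured compounds shown here, because the one measured example gave a 3.4-fold higher number from compound 1 to compound 3 (0.53 log units; beyond the scatter), a step in the same direction is expected here, and for compound 4 the expected step is a 1.9-fold higher number from compound 2 to compound 4 (0.27 log units; within the scatter). Compound 4 is therefore estimated at 30000 nM in this assay. The plausible range for compound 4 is expected to run from 12000 nM to 80000 nM.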

Compound 4, half-maximal inhibitory concentration: 6200 nM
Compound 4: the middle estimate sits 4.8-fold (0.68 log units) above what was measured; measured number outside the range, below it.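

On the core of compound 2, lengthening the chlorinated chain gives a 2.6-fold lower number from compound 2 to compound 4 (0.41 log units; beyond the scatter) in this assay, so here the longer chain goes with a stronger result rather than a weaker one. Set beside the earlier step, this shows that the size and even the direction of this kind of chain lengthening did not carry over from one core to the other: the same change on two cores in this assay, a 3.4-fold higher number (0.53 log units; beyond the scatter) from compound 1 to compound 3 and a 2.6-fold lower number (0.41 log units; beyond the scatter) from compound 2 to compound 4, 8.8-fold (0.95 log units) apart, beyond the scatter of two such steps What this does not show is whether the core alone decides the outcome, since the two steps also sit at different places, one on a saturated chain carbon bound to a carbonyl carbon and the other two bonds along the chain from a carbonyl carbon, and each rests on a single pair of compounds.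

The compounds shown leave open how the iodo group would fare with the chain of compound 4, and how the isopropyl group would fare with the chain of compound 1, which are the pairings that would separate the core from the place in the chain. They also leave open whether a still longer chlorinated chain would continue the trend, or what an amine at the chain end would do in place of the chlorine.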